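Swapping a Trifluoromethylphenyl Group for Furanyl

The source may report more compounds than this note shows. Statements on the series, on what has been measured and on what is new or still open speak of the compounds shown alone.

Three compounds sharing one core were tested in an assay on cells (Endothelial cell) for binding affinity to Endothelin-1 receptor (Sus scrofa); a higher number here means a weaker inhibitor, a lower number a stronger inhibitor. Compound 1 `COc1cccc(Oc2c(NS(=O)(=O)c3ccc(C(C)(C)C)cc3)ncnc2OCCOc2ncc(C)cn2)c1` gives 0.86 nM, and compound 2 `CSc1cnc(OCCOc2ncnc(NS(=O)(=O)c3ccc(C(C)(C)C)cc3)c2-c2ccc(C(C)C)cc2)nc1` gives 1.2 nM. Compound 3 `CSc1cnc(OCCOc2ncnc(NS(=O)(=O)c3ccc(C(C)(C)C)cc3)c2-c2ccc(C(F)(F)F)cc2)nc1` gives 0.0017 nM, the lowest of the three numbers and therefore the strongest inhibitor among them, with compound 1 the nearest and compound 2 the furthest away. Among the measured compounds shown here, the one single-point step measured here is a 710-fold lower number from compound 2 to compound 3 (2.85 log units; beyond the scatter).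

Compound 4 `CSc1cnc(OCCOc2ncnc(NS(=O)(=O)c3ccc(C(C)(C)C)cc3)c2-c2ccco2)nc1` is compound 3 with one change: furan-2-yl in place of 4-(trifluoromethyl)phenyl on an aromatic carbon. For the measured compounds named here, no measured step involves a furan ring, so the only guide is the step from compound 2 to compound 3, which shows that the group at this position can move the number by a very large amount. Since compound 2, which carries a ring without trifluoromethyl at this position, gives 1.2 nM, the expectation is that removing the trifluoromethylphenyl group of compound 3 leads to a large rise, roughly a 470-fold higher number from compound 3 to compound 4 (2.67 log units; beyond the scatter). Compound 4 is therefore expected to give about 0.8 nM, within a range from 0.03 nM to 20 nM.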

Compound 4, half-maximal inhibitory concentration: 2.9 nM
Compound 4: middle estimate off by 3.6-fold (0.56 log units), on the low side; the range from low to high includes it.
By their numbers in this assay, from the lowest: compound 3; then compounds 1 and 2 (each within the scatter of the next); then compound 4.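

In this assay the change of 4-(trifluoromethyl)phenyl to furan-2-yl brings a 1700-fold higher number from compound 3 to compound 4 (3.23 log units; beyond the scatter) and so removes nearly all of the exceptional strength of compound 3. Against the 4-isopropylphenyl group, the same furan-2-yl brings only a 2.4-fold higher number from compound 2 to compound 4 (0.38 log units; beyond the scatter) even though the ring is smaller and contains oxygen, so among these three groups the 4-(trifluoromethyl)phenyl group alone gives the very low number. Nothing available here explains why this one group stands so far apart.

On these data alone, it remains open how a plain phenyl, a 4-chlorophenyl or a 4-methylphenyl group would compare at this position, and so whether the very low number needs the trifluoromethyl group specifically. Also open, as far as these compounds go, is whether a trifluoromethyl group placed on the furan ring would bring the number back down.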